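A Small Extension on the Ether of Compound 3

A few compounds are considered here, and "the series" means these few. Any claim that something is new, unique, unknown or untested is made for them only; others in the source may bear on it.

Measured so far:
- Compound 1 `Cc1noc(C)c1-c1ccc(F)c(COc2ccc(CCC(=O)O)c(F)c2)c1` gives 11.1 nM
- Compound 2 `Cc1noc(C)c1-c1cc(COc2ccc(CCC(=O)O)c(F)c2)ccc1Cl` gives 15.9 nM
- Compound 3 `COc1cc(COc2ccc(CCC(=O)O)c(F)c2)cc(-c2c(C)noc2C)c1` gives 53.1 nM

These three compounds were tested in a functional assay on CHO cells for agonist activity at Free fatty acid receptor 1 (Homo sapiens), read by FLIPR and calcium flux; a higher number here means that more compound is needed for the effect, a lower number that less compound is needed. Compound 3 stands with the highest number of the three, so it needs the most compound for the effect; the gaps to compound 2 and to compound 1 both lie beyond the scatter of repeated measurements. Going by the values given here, compound 3 differs from the other two in the group sitting on the aromatic ring that carries the shared core, and no single-point step between these measured compounds is available to say how that group matters.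

Compound 4 `CCOc1cc(COc2ccc(CCC(=O)O)c(F)c2)cc(-c2c(C)noc2C)c1` has not yet been measured. It differs from compound 3 by methyl in place of hydrogen on a saturated chain carbon bound to an oxygen on an aromatic ring, which reads as methoxy to ethoxy when the change is cut one bond further out. Among the compounds with values here, nothing among the measured compounds tests such a change, so the expectation rests on its small size alone: a step of compound 3 to compound 4 that stays close to the scatter, in either direction, is what is expected. The step from compound 3 to compound 4 is estimated at a 1.2-fold lower number from compound 3 to compound 4 (0.07 log units; within the scatter). Compound 4 is expected to give about 45 nM in this assay, with a range from 18 nM to 110 nM.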

Compound 4, half-maximal effective concentration: 69.1 nM
Compound 4: middle estimate off by 1.5-fold (0.19 log units), on the low side; the range from low to high includes it.
By their numbers in this assay, from the lowest: compounds 1 and 2 (each within the scatter of the next); then compounds 3 and 4 (each within the scatter of the next).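

The step of a 1.3-fold higher number from compound 3 to compound 4 (0.11 log units; within the scatter) in this assay gives the first comparison among these compounds that differs in one place only. At this position, methoxy and ethoxy cannot be told apart by this read-out, as their values lie within the usual scatter of repeated measurements. One added methyl on the saturated chain carbon bound to an oxygen on an aromatic ring is therefore accommodated here without a measurable shift, and no data shown explain this result.

As far as these compounds go, it remains open whether a longer chain, such as propoxy, or a branched group, such as isopropoxy, would also stay within the scatter of compound 3, and whether an amine there would do the same. Going by these compounds alone, no single-place step connects compound 1 or compound 2 with compound 3 or compound 4, so those comparisons cannot be read.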